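The compounds below may be only part of what the source reports. "The series", "measured", "known", "first", "only" and "open" are said of these compounds alone.

The series shares one core, seen in compound 1 `Cc1ccccc1NNC(=O)c1ccc(NS(=O)(=O)c2cnc(O)nc2O)cc1`, compound 2 `Cc1cccc(NNC(=O)c2ccc(NS(=O)(=O)c3cnc(O)nc3O)cc2)c1` and compound 3 `O=C(NNc1ccccc1F)c1ccc(NS(=O)(=O)c2cnc(O)nc2O)cc1`; the three differ only in the group on an amine nitrogen. In a functional assay on SGC-7901 cells (Homo sapiens) for antiproliferative activity, read by MTT assay, with a stated time of 24 h (a higher number here means a weaker inhibitor, a lower number a stronger inhibitor), compound 1 gives > 20000 nM, a limit of the assay rather than a number. Compound 2 likewise gives > 20000 nM, again a limit. Among the compounds with values here, compound 3 is the only one with a number, giving 16000 nM in this assay. The step that the two limits leave unreadable from compound 1 to compound 2 cannot be read, both ends being limits. The steps of an at least 1.2-fold lower number from compound 1 to compound 3 (0.09 log units; that floor lies within the scatter) and an at least 1.2-fold lower number from compound 2 to compound 3 (0.09 log units; that floor lies within the scatter) are each only a floor, and that floor lies within the scatter; all three compounds sit at the weak end of this assay, as the limit of > 20000 nM in this assay, at which 2 of the 3 values shown sit, shows.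

Compound 4 `Cc1ccc(C(=O)NNC(=O)c2ccc(NS(=O)(=O)c3cnc(O)nc3O)cc2)cc1` is not yet measured. The change from compound 3 is (4-methylphenyl)carbonyl in place of 2-fluorophenyl on an amine nitrogen. Within the data shown here, no measured step bears directly on this change: the steps so far swap one aryl group for another, whereas here a (4-methylphenyl)carbonyl enters. Among the measured compounds shown here, with every compound so far at or near the limit, the expectation is that compound 4 stays weak, the step of a 1.1-fold lower number from compound 3 to compound 4 (0.03 log units; within the scatter) expected to show no clear direction beyond the scatter. Compound 4 is therefore estimated at 15000 nM, between 5000 nM and 40000 nM, in this assay, with a real chance that only a limit is returned.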

Compound 4, half-maximal inhibitory concentration: > 20000 nM
Compound 4: a limit, no number (the forecaster's own chance of this, stated with the estimate: 45%); middle value at least 1.3-fold (0.12 log units) from the limit.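

Within the data shown here, on the amine nitrogen whose other neighbour is the amide-type nitrogen, (4-methylphenyl)carbonyl brings a carbonyl to this place for the first time, and in this assay compound 4 gives > 20000 nM, a limit of the assay and not a number. Among these compounds, the one readable step is an at least 1.2-fold higher number from compound 3 to compound 4 (0.09 log units; that floor lies within the scatter), so it sets only a floor and shows no clear direction for this change from an aryl group to a carbonyl-linked one. The steps to compound 4 from compound 1 and from compound 2 cannot be read, and the new group does not yet bring a number into the measurable range, leaving the series at the weak end: the limit of > 20000 nM in this assay, at which 3 of the 4 values shown sit.

Open, on these data alone, is whether a benzyl group or a longer alkyl chain on this nitrogen would move the value clearly away from the limit in this assay. Also open, as far as these compounds go, is whether a carboxylic acid or an amine on the ring of the (4-methylphenyl)carbonyl group would give a number that can be compared at all.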